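A Second Chloro on Compound 1: Solubility Expectation

This account rests on a few compounds, and the source may have more. Where it says the series, first, only, none or still open, it means among the compounds named here.

The measured compounds:
compound 1, `CCOC(=O)c1c(-c2cccc(Cl)c2)[nH]c2cccc(OC)c2c1=O`, > 100000 nM
compound 2, `CCOC(=O)c1c(-c2ccc(Cl)cc2)[nH]c2cc(OC)ccc2c1=O`, 3000 nM

Both compounds were tested in a physicochemical assay for solubility, in phosphate buffer, at pH 7.4; a higher number here means a more soluble compound, a lower number a less soluble compound. For compound 1 the result is only a limit, > 100000 nM, so compound 1 stands at the limit of > 100000 nM in this assay, at which 1 of the 2 values shown sits, and its true solubility is not pinned down. Compound 2, by contrast, gives a definite reading in this assay of 3000 nM. Going by the values given here, compound 1 and compound 2 differ from each other in more than one place, so the gap between their two values cannot be traced to a single change; the two values show only that compound 1 is more soluble than compound 2.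

The compound that is not yet measured is compound 3, `CCOC(=O)c1c(-c2ccc(Cl)c(Cl)c2)[nH]c2cccc(OC)c2c1=O`. It is made from compound 1 by one change, (chloro in place of hydrogen on an aromatic carbon).

Because compound 1 rests at the limit of > 100000 nM in this assay, at which 1 of the 2 values shown sits, the size of the step from compound 1 cannot be read from the data. My expectation is a modest fall, the step of an at least 2.0-fold lower number from compound 1 to compound 3 (0.30 log units; that floor lies within the scatter), which may still leave compound 3 at the limit. Compound 3 is estimated at 50000 nM, between 10000 nM and 200000 nM.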

Compound 3, solubility: 39000 nM
Compound 3: the middle estimate sits 1.3-fold (0.11 log units) above what was measured; low and high end bracket the measured number.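

Going by these compounds alone, this result gives the first change at a single place, as the earlier pair differed in more than one. In this assay, a chloro group on the aromatic carbon ortho to the existing chloro group and para to a large group, which turns 3-chlorophenyl into 3,4-dichlorophenyl, gives an at least 2.5-fold lower number from compound 1 to compound 3 (0.40 log units; beyond the scatter). Compound 3 gives a definite reading of 39000 nM. Only the smallest possible size of the step is known because compound 1 rests at a limit: the limit of > 100000 nM in this assay, at which 1 of the 3 values shown sits.

The compounds shown do not tell whether this fall belongs to chloro itself, since no other group appears at this position, and a fluoro group, an amine or a carboxylic acid placed there could move the reading by a different amount or in the other direction. They also leave open whether the same change would do the same on compound 2, whose chlorophenyl ring and methoxy group are placed differently.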